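Propoxy in Place of Chloro on a Shared Core

This account rests on a few compounds, and the source may have more. Where it says the series, first, only, none or still open, it means among the compounds named here.

In a functional assay on the whole organism with Rattus norvegicus as the target, at a dose of 3 mg/kg by the oral route (a lower number here means a weaker effect, a higher number a stronger effect of the compound at the dose given), the measured compounds give:
Compound 1 `COc1ccc(-c2cc(Cl)cc(C(=O)Nc3nn[nH]n3)n2)cc1`: 100%
Compound 2 `CCc1ccc(-c2cc(Cl)cc(C(=O)Nc3nn[nH]n3)n2)cc1`: 100%
Compound 3 `Nc1ccc(-c2cc(Cl)cc(C(=O)Nc3nn[nH]n3)n2)cc1`: 100%

Compound 3 stands level with compounds 1 and 2 at the digits shown. The three measured steps, no change at the digits printed from compound 1 to compound 2 (within the scatter), no change at the digits printed from compound 1 to compound 3 (within the scatter) and no change at the digits printed from compound 2 to compound 3 (within the scatter), were all within the scatter, and each swapped a group on an aromatic carbon while leaving the chloro untouched. Compound 4 `CCCOc1cc(C(=O)Nc2nn[nH]n2)nc(-c2ccc(N)cc2)c1` differs from compound 3 as follows: propoxy in place of chloro on an aromatic carbon. Going by the values given here, no measured step tests this place, so the measured steps bear on it only indirectly, showing a series that so far tolerates change without loss. Among the compounds with values here, since every measured compound sits at full inhibition, a drop is the only direction a change could take. The expected step is a number 15 percentage points lower from compound 3 to compound 4 (beyond the scatter). For compound 4 the estimate is 85%, with a range from 50% to 100%.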

Compound 4, a percentage reported as inhibition, in the whole organism at one dose (the size of the read-out at that dose, not a potency): 68%
For compound 4 the middle estimate is 17 percentage points above the measured one; the range from low to high includes it.
By their numbers in this assay, from the lowest: compound 4; then compounds 1, 2 and 3 (each within the scatter of the next).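

Opposite the ring nitrogen, propoxy in place of chloro gives a number 32 percentage points lower from compound 3 to compound 4 (beyond the scatter) in this assay, the only step shown that lies beyond the scatter. This position therefore does not share the tolerance seen for the changes among compounds 1, 2 and 3, which were made on the other aromatic ring. Nothing available here explains the loss. The compounds shown leave open whether the oxygen or the chain length matters, which a shorter ethoxy or a longer butoxy at this place could help separate. As far as these compounds go, whether propoxy would cost as much alongside a group other than the 4-aminophenyl group also remains open.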